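The source may report more compounds than this note shows. Statements on the series, on what has been measured and on what is new or still open speak of the compounds shown alone.

Compound 1 `COc1ccc(-c2cc(COc3ccccc3-c3nc4ccccc4s3)on2)cc1` — 34100 nM
Compound 2 `COc1cc(-c2cc(COc3ccccc3-c3nc4ccccc4s3)on2)cc(OC)c1OC` — 42900 nM

In an ADME assay on MCF-10A cells (Homo sapiens) for cytotoxicity, read by MTT assay, with a stated time of 24 h (a lower number here means a stronger inhibitor, a higher number a weaker inhibitor), compound 1 gives 34100 nM and compound 2 gives 42900 nM; the two numbers lie within the scatter of each other, compound 1 holding the lower one. Compound 3 `Fc1ccccc1-c1cc(COc2ccccc2-c2nc3ccccc3s2)on1` is still unmeasured. Its change from compound 1 is 2-fluorophenyl in place of 4-methoxyphenyl on an aromatic carbon. For the measured compounds named here, no step between measured compounds is available, so the series gives no measured size for such a change; both measured numbers are high, and nothing beyond the scatter is expected in either direction. Compound 3 is estimated at 35000 nM, within 12000 nM to 100000 nM, an expected step of a 1.0-fold higher number from compound 1 to compound 3 (0.01 log units; within the scatter).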

Compound 3, half-maximal inhibitory concentration: 42500 nM
Compound 3: the middle estimate sits 1.2-fold (0.08 log units) below what was measured; the measured number falls inside the stated range.
By their numbers in this assay, from the lowest: compounds 1, 3 and 2 (each within the scatter of the next).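

In this assay, for the compounds shown here, the first measured step at this position, 2-fluorophenyl in place of 4-methoxyphenyl, reads a 1.2-fold higher number from compound 1 to compound 3 (0.10 log units; within the scatter). In this single pair, then, a different substituent and its placement on the phenyl ring, along with the absence of the hydrogen-bond acceptor carried by the leaving group, leave the number within the scatter. No other measurement bears on this result. As far as these compounds go, whether an amine or a carboxylic acid on this phenyl ring would shift the number beyond the scatter stays open. So does the effect of replacing the phenyl ring with a saturated alkyl chain.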